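Shifting the aryl group on the amide nitrogen

The source may hold more compounds than are shown below. What is called first, only, known or untested is meant among the compounds shown, and "the series" means these compounds.

Compound 1, `O=C(O)C1=Cc2ccccc2OC1(OCc1cc(-c2ccc(F)cc2)no1)C(F)(F)F`, in a functional assay on HeLa cells (Homo sapiens) for inhibition, read by MTT assay, with a stated time of 24 h (a higher number here means a weaker inhibitor, a lower number a stronger inhibitor), gives > 150000 nM, which is a limit of the assay and not a number.
Compound 2, `CCOC(=O)C1=Cc2ccccc2OC1(OCc1cn(-c2ccc(C)cc2)nn1)C(F)(F)F`, in this assay gives 25100 nM.
Compound 3, `CCOC(=O)C1=Cc2ccccc2OC1(OCc1cn(CC(=O)Nc2cccc(F)c2)nn1)C(F)(F)F`, in this assay gives > 150000 nM, again a limit of the assay.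

Compound 3 stands at the limit, and so does compound 1; only compound 2 has a number. Among the compounds with values here, the one measured step, an at least 5.9-fold higher number from compound 2 to compound 3 (0.77 log units; beyond the scatter), concerns a different change and gives no guide to the present one. Compound 4, `CCOC(=O)C1=Cc2ccccc2OC1(OCc1cn(CC(=O)Nc2ccc(C)cc2)nn1)C(F)(F)F`, differs from compound 3 by 4-methylphenyl in place of 3-fluorophenyl on an amide-type nitrogen. Within the data shown here, no measured pair shows this change, so there is no step to lean on. Since compound 3 sits at the limit of > 150000 nM in this assay, at which 2 of the 3 values shown sit, the scale there is compressed, and a change of this kind is expected to leave compound 4 within the scatter of compound 3, that is, no step beyond the scatter in this assay is expected. Compound 4 is therefore estimated at 150000 nM, within 60000 nM to 300000 nM, an expected step of a number no higher from compound 3 to compound 4 (the limit leaves the size open).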

Compound 4, half-maximal inhibitory concentration: 67400 nM
The estimate for compound 4 lay 2.2-fold (0.35 log units) above the measured number; measured number inside the range.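

In this assay the aryl group on the amide-type nitrogen proves to count, with an at least 2.2-fold lower number from compound 3 to compound 4 (0.34 log units; beyond the scatter) for 4-methylphenyl in place of 3-fluorophenyl. From the compounds shown here alone, the full size of this step stays open because the value of compound 3 is a limit: the limit of > 150000 nM in this assay, at which 2 of the 4 values shown sit. Unlike the earlier step from the triazole series' aryl compound, the other new step keeps the 4-methylphenyl group and changes only how it is attached, and a 2.7-fold higher number from compound 2 to compound 4 (0.43 log units; beyond the scatter) shows that ((4-methylphenyl)carbamoyl)methyl on the aromatic nitrogen still gives a weaker inhibitor than 4-methylphenyl there.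

Open, going by these compounds, is how 4-fluorophenyl or 3-methylphenyl would fare on the amide-type nitrogen, and so whether the gain follows the group itself or where it sits. Equally open, on these data alone, is how an aryl group carrying an amine or a carboxylic acid would read in this assay.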